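This account rests on a few compounds, and the source may have more. Where it says the series, first, only, none or still open, it means among the compounds named here.

Compound 1 `COc1cc(-c2nnc3n2CCCC3c2ccc(Cl)c(Cl)c2)ccc1-c1cnc(C)o1`: 3.2
Compound 2 `COc1cc(-c2nnc3n2CCCC3(O)c2ccc(Cl)c(Cl)c2)ccc1-c1cnc(C)o1`: 2.9

Both numbers come from a physicochemical assay for lipophilicity, measured as chromatographic lipophilicity, at pH 7.4; a higher number here means a more lipophilic compound, a lower number a more polar compound. Compound 2, at 2.9, lies within the scatter of compound 1, at 3.2, so the two cannot be told apart on this measure. Compound 3 `COc1cc(-c2nnc3n2CCCC3(OC)c2ccc(Cl)c(Cl)c2)ccc1-c1cnc(C)o1` differs from compound 2 in one place: methyl in place of hydrogen on an oxygen on a saturated carbon. In words, this is methyl in place of hydrogen on an oxygen on a saturated carbon, or hydroxy to methoxy. For the measured compounds named here, no measured pair shows this exact change. Going by the values given here, the closest guide is the one measured step, which swapped hydrogen for hydroxy on a saturated ring carbon: a number 0.30 log units lower from compound 1 to compound 2 (within the scatter). With so small a guide, only a small upward move is expected, and it may not clear the scatter. The expected step is a number 0.30 log units higher from compound 2 to compound 3 (within the scatter). For compound 3 the estimated value is 3.2, with an expected range from 2.8 to 3.6.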

Compound 3, distribution coefficient: 3.7
The estimate for compound 3 lay 0.50 log units below the measured number; the measured number lies above the stated range.
By their numbers in this assay, from the lowest: compounds 2 and 1 (each within the scatter of the next); then compound 3.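

At this saturated ring carbon, the group placed there can move the reading in this assay beyond the scatter: capping the hydroxy with methyl gives a clear step (a number 0.80 log units higher from compound 2 to compound 3 (beyond the scatter)), and methoxy in place of hydrogen also clears the scatter (a number 0.50 log units higher from compound 1 to compound 3 (beyond the scatter)). Hydroxy in place of hydrogen did not clear it (a number 0.30 log units lower from compound 1 to compound 2 (within the scatter)), so the two oxygen-bearing groups do not read alike at this carbon, and the earlier pair alone could not have shown that. No measurement at hand explains this difference between hydroxy and methoxy.

The compounds shown leave open how a longer chain on that oxygen, such as ethoxy, or an amine on the same carbon would read. From the compounds shown here alone, they also share one core, so whether the methoxy step holds on any other core remains unknown.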